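This account rests on a few compounds, and the source may have more. Where it says the series, first, only, none or still open, it means among the compounds named here.

The compounds measured so far:
compound 1, `CC(C)N(Cc1cccc(OCCCCCC(=O)O)c1)C(=O)c1ccc(-c2cccc3ccccc23)cc1`, > 26000 nM
compound 2, `CC(C)N(Cc1cccc(OCCCCCC(=O)O)c1)C(=O)c1ccc(-c2cccc(-c3ccccc3)c2)cc1`, > 26000 nM
compound 3, `CC(C)N(Cc1cccc(OCCCCCC(=O)O)c1)C(=O)c1ccc(-c2ccsc2)cc1`, > 26000 nM

Compound 3 was tested in an ADME assay on Raji cells (Homo sapiens) for cytotoxicity, read by CellTiter-Glo and resazurin assay, with a stated time of 72 h; on this read-out higher numbers stand for an effect only at larger amounts of compound and lower numbers for an effect already at smaller amounts. In this assay compound 3 gives > 26000 nM, which is a limit of the assay and not a number. In this assay compound 1 gives > 26000 nM, also a limit. In this assay compound 2 gives > 26000 nM, again a limit. All three values share (the limit of > 26000 nM in this assay, at which 3 of the 3 values shown sit). The three steps between them, a step that the two limits leave unreadable from compound 1 to compound 2, a step that the two limits leave unreadable from compound 1 to compound 3 and a step that the two limits leave unreadable from compound 2 to compound 3, therefore cannot be read in size or direction.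

Compound 4 `CC(C)N(Cc1cccc(OCCCCCC(=O)O)c1)C(=O)c1ccc(-c2ccc3c(c2)OCCO3)cc1` differs from compound 3 by 2,3-dihydro-1,4-benzodioxin-6-yl in place of thiophen-3-yl on an aromatic carbon. Going by the values given here, no measured step gives a readable size for an aryl exchange at this position, so nothing points to a change beyond the scatter in this assay. Every aryl variant shown sits at the limit, and compound 4 is expected to do the same. For compound 4 the estimate is 35000 nM, with a range from 15000 nM to 90000 nM. The step that the limit leaves unreadable from compound 3 to compound 4 is expected to stay within the scatter.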

Compound 4, half-maximal effective concentration: > 21900 nM
Compound 4: a limit, no number; the forecaster's own chance of this, stated with the estimate: 85%; the middle value lies beyond the limit too.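

In this assay compound 4 gives > 21900 nM, a limit of the assay and not a number. The steps to it from compound 1, compound 2 and compound 3, which also sit at limits, cannot be read in size or direction. The compounds shown leave open at what concentration, if any, these four compounds reach a half-maximal effect in this assay.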